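Methanesulfonamido in Place of Hydrogen: Expected Inhibition

A few compounds are considered here, and "the series" means these few. Any claim that something is new, unique, unknown or untested is made for them only; others in the source may bear on it.

Measured compounds:
compound 1, `Oc1cccc2cc(-c3ccccc3)ccc12`: < 10%
compound 2, `O=[N+]([O-])c1ccc(-c2ccc3c(O)cccc3c2)cc1`: 15%

In an assay for binding affinity to 17-beta-hydroxysteroid dehydrogenase type 1 (Homo sapiens), with a stated time of 20 min, tested at 1 uM (on this read-out higher numbers stand for more inhibition at the one concentration tested (going by the name of the read-out) and lower numbers for less inhibition), compound 1 gives < 10%, which is a limit of the assay and not a number; compound 1 is the one of the two that sits at the limit of < 10% in this assay, at which 1 of the 2 values shown sits. Compound 2 gives 15% in this assay. For the measured compounds named here, the one measured step, a number at least 5 percentage points higher from compound 1 to compound 2 (that floor lies within the scatter), comes from nitro in place of hydrogen on an aromatic carbon, and its floor lies within the scatter.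

Compound 3, `CS(=O)(=O)Nc1ccc(-c2ccc3c(O)cccc3c2)cc1`, differs from compound 1 by methanesulfonamido in place of hydrogen on an aromatic carbon. Going by the values given here, the only step on record, from compound 1 to compound 2, is small, so the step from compound 1 to compound 3 is expected to be small too, at most a modest rise: a number at least 5 percentage points higher from compound 1 to compound 3 (that floor lies within the scatter). Compound 3 is therefore estimated to give 15% in this assay, with a range from 0% to 35%, and a fair chance that only a limit is reported.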

Compound 3, a percentage reported as inhibition, at one concentration (the size of the read-out at that concentration, not a potency): 52%
Beside the measured number, compound 3's estimate is 37 percentage points below it, and the stated range ends below it.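

At this position, on an aromatic carbon para to a large group, methanesulfonamido in place of hydrogen brings a clear rise in this assay: a number at least 42 percentage points higher from compound 1 to compound 3 (beyond the scatter). The rise depends on which group enters, not merely on the position being filled, as methanesulfonamido in place of nitro gives a number 37 percentage points higher from compound 2 to compound 3 (beyond the scatter). The first of these steps gives only a floor for the size of the change, since compound 1 carries a limit of the assay and not a number: the limit of < 10% in this assay, at which 1 of the 3 values shown sits.

The compounds shown do not tell which part of methanesulfonamido carries the rise, the nitrogen with its hydrogen or the sulfur with its two oxygens. They also leave open how a plain amine, an acetamido group or a carboxylic acid would read at this same position.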